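The source may report more compounds than this note shows. Statements on the series, on what has been measured and on what is new or still open speak of the compounds shown alone.

Measured so far in a functional assay on TK-10 cells (Homo sapiens) for inhibition, read by sulforhodamine B assay, with a stated time of 48 h; on this read-out lower numbers stand for higher toxicity in this test and higher numbers for lower toxicity in this test:

- compound 1, `Nc1cc(N)c2nc(-c3ccccc3)c(Oc3ccc(Cl)c(Cl)c3)nc2c1`
- compound 2, `CCOC(=O)[C@H](CCC(=O)O)NC(=O)c1ccc(CNc2nc3cc(N)cc(N)c3nc2-c2ccccc2)cc1`
- compound 3, `Nc1cc(N)c2nc(-c3ccccc3)c(NCc3ccc(Cl)c(Cl)c3)nc2c1`

In this assay compound 1 gives < 100000 nM, which is a limit of the assay and not a number. In this assay compound 2 likewise gives < 100000 nM, again a limit. For the measured compounds named here, compound 3 is the one member of the series with a number, 72400 nM in this assay. On the numbers shown compound 3 therefore stands alone; the other two entries sit at the limit of < 100000 nM in this assay, at which 2 of the 3 values shown sit, so no ordering among the three can be read from them.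

Compound 4, `COc1ccc(CNc2nc3cc(N)cc(N)c3nc2-c2ccccc2)cc1OC`, is to be measured in this assay. It differs from compound 3 in one place: 3,4-dimethoxyphenyl in place of 3,4-dichlorophenyl on a saturated chain carbon bound to a nitrogen on an aromatic ring. Going by the values given here, no pair of measured compounds in this set differs in a single place, so no measured step exists to guide the size of this change. Among the compounds with values here, with only one number in hand, the expectation is a step of no more than the usual scatter in either direction, with a fair chance that the assay again reports only a limit. Compound 4 is thus estimated at 80000 nM in this assay, within 35000 nM to 160000 nM, meaning an expected step of a 1.1-fold higher number from compound 3 to compound 4 (0.04 log units; within the scatter).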

Compound 4, concentration lethal to 50% of the cells: 64600 nM
The estimate for compound 4 lay 1.2-fold (0.09 log units) above the measured number; the range from low to high includes it.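

In this assay, the place on a saturated chain carbon bound to a nitrogen on an aromatic ring now has its first measured step: 3,4-dimethoxyphenyl in place of 3,4-dichlorophenyl gives a 1.1-fold lower number from compound 3 to compound 4 (0.05 log units; within the scatter). The entering group carries 2 hydrogen-bond acceptors and the leaving group 0, yet the read-out does not move beyond the scatter. Compound 1 and compound 2 still give no number, each entry being a limit of the assay: the limit of < 100000 nM in this assay, at which 2 of the 4 values shown sit.

Going by these compounds, whether an amine or a carboxylic acid on the phenyl ring, or a longer chain in place of the saturated chain carbon, would give a step beyond the scatter stays open. A single step at one place also says nothing about changes elsewhere on the shared core.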